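The compounds below may be only part of what the source reports. "The series", "measured", "known", "first", "only" and "open" are said of these compounds alone.

In a functional assay on MT4 cells (Homo sapiens) for cytotoxicity (on this read-out lower numbers stand for higher toxicity in this test and higher numbers for lower toxicity in this test), compound 3 (`Cc1cn(C2CC(N=[N+]=[N-])C(COC(=O)CCCC(=O)O)O2)c(=O)[nH]c1=O`) gives > 50000 nM as a limit of the assay, not a number. Compound 2 (`Cc1cn(C2CC(N=[N+]=[N-])C(COC(=O)OCCCCCCO)O2)c(=O)[nH]c1=O`) gives > 50000 nM as a limit too. Compound 4 (`Cc1cn(C2CC(N=[N+]=[N-])C(COC(=O)CCCC(=O)OC(C)(C)C)O2)c(=O)[nH]c1=O`) differs from compound 3 by tert-butyl in place of hydrogen on an oxygen next to a carbonyl group, which turns carboxy into tert-butoxycarbonyl. Going by the values given here, the one measured step is a step that the two limits leave unreadable from compound 2 to compound 3 and offers no size to carry over. Compound 1 (`Cc1cn(C2CC(N=[N+]=[N-])C(COC(=O)NCCCC(=O)OC(C)(C)C)O2)c(=O)[nH]c1=O`), which also carries tert-butoxycarbonyl, gives > 50000 nM as a limit as well. Among the compounds with values here, that leaves the limit of > 50000 nM in this assay, at which 3 of the 3 values shown sit, as the only guide, so no step beyond the scatter is expected in this assay, in either direction. The expected step is (a number no higher from compound 3 to compound 4 (the limit leaves the size open)) in size. Compound 4 is estimated at 50000 nM within a range of 20000 nM to 100000 nM and will probably read as a limit again.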

Compound 4, half-maximal cytotoxic concentration: > 50000 nM
Compound 4: only a limit was reported (the forecaster's own chance of this, stated with the estimate: 85%); the middle value sits exactly at the limit.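

Compound 2, compound 3 and compound 4 all stand at a limit in this assay, and the steps among them cannot be read. Going by these compounds, whether tert-butoxycarbonyl in place of carboxy changes toxicity at all stays open.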